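A few compounds are considered here, and "the series" means these few. Any claim that something is new, unique, unknown or untested is made for them only; others in the source may bear on it.

Compound 2 `CCOC(=O)C1=C(N)Oc2ccc(-c3cc(OC)cc(OC)c3)cc2C1CC(=O)c1ccccc1` gives 41000 nM in a functional assay on HL60/MX2 cells (Homo sapiens) for inhibition, with a stated time of 48 h (on this read-out higher numbers stand for weaker inhibition and lower numbers for stronger inhibition), the highest of the three numbers measured and so the weakest inhibitor of this small set. Compound 1 `CCOC(=O)CC1C(C(=O)OCC)=C(N)Oc2ccc(-c3cc(OC)cc(OC)c3)cc21` gives 1700 nM, and compound 3 `C#CCOC(=O)CC1C(C(=O)OCC#C)=C(N)Oc2ccc(-c3cccc(N)c3)cc21` gives 540 nM. Within the data shown here, the only single-place step among the measured compounds, a 24-fold higher number from compound 1 to compound 2 (1.38 log units; beyond the scatter), concerns a different part of the molecule. Compound 4 `C#CCOC(=O)C1=C(N)Oc2ccc(-c3cc(OC)cc(OC)c3)cc2C1CC(=O)c1ccccc1` differs from compound 2 by ethynyl in place of methyl on a saturated chain carbon bound to an oxygen next to a carbonyl group. Compound 3 carries the same propargyloxycarbonyl groups, but it differs from compound 2 in more than one place, so its value cannot be traced to the ester change alone. Among the measured compounds shown here, no measured step therefore bears directly on this change, and the expected step of no change at the digits printed from compound 2 to compound 4 (within the scatter) is none beyond the scatter. Compound 4 is estimated at 41000 nM, within 12000 nM to 130000 nM.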

Compound 4, half-maximal inhibitory concentration: 5900 nM
For compound 4 the middle estimate is 6.9-fold (0.84 log units) above the measured one; measured number outside the range, below it.
By their numbers in this assay, from the lowest: compound 3; then compound 1; then compound 4; then compound 2.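

Ethynyl in place of methyl on this saturated chain carbon bound to an oxygen next to a carbonyl group gives a 6.9-fold lower number from compound 2 to compound 4 (0.84 log units; beyond the scatter) in this assay, so inhibition is stronger with the propargyl ester than with the ethyl ester. Among these compounds, this is the first measured step at this position, and it shows that the ester's outer end affects the result. Nothing available explains why this change has this effect. Still open, going by these compounds, is whether a carboxylic acid or a longer chain, such as butyl, would go further, and whether ethyl to propargyl gives a similar step when the other side chains differ.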